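Swapping a Ring Nitrogen for Carbon in a Cytotoxicity Series

The source may report more compounds than this note shows. Statements on the series, on what has been measured and on what is new or still open speak of the compounds shown alone.

Measured compounds:
compound 1 `Oc1ccc(-c2cc(-c3cccc(Cl)c3)nc(-c3ccccn3)c2)cc1`, 25400 nM
compound 2 `Oc1cccc(-c2cc(-c3cccc(Cl)c3)nc(-c3ccccn3)c2)c1`, "not determined" (no result reported)
compound 3 `Oc1ccc(-c2cc(-c3ccccn3)nc(-c3ccccc3Cl)c2)cc1`, "not determined" (no result reported)

Three compounds of a shared core were tested in an ADME assay on HEK293 cells (Homo sapiens) for cytotoxicity, read by CCK-8 assay and cell counting, with a stated time of 2 days; on this read-out higher numbers stand for weaker inhibition and lower numbers for stronger inhibition. Compound 1 gives 25400 nM, a weak effect on cell growth. Going by the values given here, compound 2 and compound 3 carry the same kind of groups arranged differently, but in this assay compound 2 gives "not determined" (no result reported) and compound 3 gives "not determined" (no result reported), so compound 1 stands alone as the only measured point: it is neither strongest nor weakest, simply the one value in hand.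

The step to compound 4 `Oc1ccc(-c2cc(-c3ccccc3)nc(-c3cccc(Cl)c3)c2)cc1` is a single exchange on the core: phenyl in place of pyridin-2-yl on an aromatic carbon. Everything else about the molecule stays as in compound 1.

Among the compounds with values here, with no pair of measured compounds to show how such an exchange shifts the read-out in this assay, the expectation rests on the weak value of compound 1 alone. A change of one ring atom in a group of this size is expected to move the number little, and the step from a 1.0-fold lower number from compound 1 to compound 4 (0.01 log units; within the scatter) is expected to stay within the scatter of repeated runs. Compound 4 is therefore estimated at 25000 nM, with a range from 8000 nM to 80000 nM.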

Compound 4, half-maximal inhibitory concentration: 2820 nM
The estimate for compound 4 lay 8.9-fold (0.95 log units) above the measured number, outside the stated range (below it).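

In this assay, this position proves sensitive to a change of a single ring atom: phenyl in place of pyridin-2-yl gives a 9.0-fold lower number from compound 1 to compound 4 (0.95 log units; beyond the scatter), a step beyond the usual scatter of repeated runs. Both groups are six-membered aromatic rings with 6 heavy atoms and no net charge, and they differ in that pyridin-2-yl holds a ring nitrogen where phenyl holds carbon. Going by these compounds alone, at this spot on the core, then, that one exchange is enough to give clearly stronger inhibition, a first sign that the group here is not a neutral bystander in this read-out. Nothing at hand explains why the number moves.

This single pair cannot show whether the shift belongs to the removal of the ring nitrogen itself or to something particular to this pair of groups. Going by these compounds, how the number would respond to a pyridin-3-yl ring, which keeps the nitrogen but moves it within the ring, or to a morpholine or a simple methyl at the same carbon, remains open.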